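Pyrimidin-2-yl Replacing Oxazol-2-yl on the Shared Core

The source may report more compounds than this note shows. Statements on the series, on what has been measured and on what is new or still open speak of the compounds shown alone.

Among the compounds with values here, compound 2 `C[C@@H](Oc1cc2oc(=O)n(CCC(=O)O)c2cc1Cl)c1ncco1` gives the higher of the two numbers so far: in an assay on HEK293 cells for inhibition of kynurenine 3-monooxygenase (Homo sapiens), read by LC-MS, with a stated time of 20 h (on this read-out higher numbers stand for weaker inhibition and lower numbers for stronger inhibition), compound 2 gives 7940 nM, whereas compound 1 `C[C@@H](Oc1cc2oc(=O)n(CCC(=O)O)c2cc1Cl)c1cccnn1` gives 631 nM. Compound 3 `C[C@@H](Oc1cc2oc(=O)n(CCC(=O)O)c2cc1Cl)c1ncccn1` differs from compound 2 by pyrimidin-2-yl in place of 1,3-oxazol-2-yl on a saturated chain carbon bound to an oxygen on an aromatic ring and a saturated chain carbon. Within the data shown here, the only measured step that bears on this is a 13-fold higher number from compound 1 to compound 2 (1.10 log units; beyond the scatter), in which a six-membered ring with two hetero atoms was exchanged for 1,3-oxazol-2-yl. Reversing that kind of exchange, compound 3 is expected to move toward the number of compound 1 by a 6.6-fold lower number from compound 2 to compound 3 (0.82 log units; beyond the scatter), giving an estimated 1200 nM, between 400 nM and 3500 nM.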

Compound 3, half-maximal inhibitory concentration: 3160 nM
Beside the measured number, compound 3's estimate is 2.6-fold (0.42 log units) below it; the measured number falls inside the stated range.
By their numbers in this assay, from the lowest: compound 1; then compound 3; then compound 2.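

Pyrimidin-2-yl at this place, on a saturated chain carbon bound to an oxygen on an aromatic ring and a saturated chain carbon, goes only part of the way back: in this assay there is a 2.5-fold lower number from compound 2 to compound 3 (0.40 log units; beyond the scatter) and still a 5.0-fold higher number from compound 1 to compound 3 (0.70 log units; beyond the scatter) remains. A six-membered aromatic ring with 2 hetero atoms is therefore not enough to match compound 1, since pyrimidin-2-yl and pyridazin-3-yl are not interchangeable here. No supporting evidence accounts for this difference. The compounds shown leave open how phenyl or pyridin-2-yl would fall at this place.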